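The source may hold more compounds than are shown below. What is called first, only, known or untested is meant among the compounds shown, and "the series" means these compounds.

Compound 1 `CNc1ncnc2c1c(-c1ccsc1)cn2[C@@H]1O[C@H](CO)[C@@H](O)[C@H]1O`: > 20000 nM
Compound 2 `CN(C)c1ncnc2c1c(-c1ccsc1)cn2[C@@H]1O[C@H](CO)[C@@H](O)[C@H]1O`: > 20000 nM
Compound 3 `Cc1ncnc2c1c(-c1ccoc1)cn2[C@@H]1O[C@H](CO)[C@@H](O)[C@H]1O`: > 20000 nM

In a functional assay on HCT-116 cells (Homo sapiens), read by MTT assay, with a stated time of 72 h (a lower number here means a stronger inhibitor, a higher number a weaker inhibitor), compound 3 gives > 20000 nM, which is a limit and not a number. It has no readable rank among the measured compounds, as the record shows (the limit of > 20000 nM in this assay, at which 3 of the 3 values shown sit). Compound 4 `Cc1ncnc2c1c(-c1ccsc1)cn2[C@@H]1O[C@H](CO)[C@@H](O)[C@H]1O` differs from compound 3 by one swap: thiophen-3-yl in place of furan-3-yl on an aromatic carbon. Compound 1 and compound 2 also carry thiophen-3-yl, yet both stop at the limit. Among the measured compounds shown here, the only measured step is a step that the two limits leave unreadable from compound 1 to compound 2, and it is a different change, so no size carries over. A further limit is therefore the likeliest result, with no step beyond the scatter expected. The expected step is a number no higher from compound 3 to compound 4 (the limit leaves the size open). For compound 4 the estimated value is 20000 nM, with an expected range of 6000 nM to 40000 nM.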

Compound 4, half-maximal inhibitory concentration: 1430 nM
Compound 4: the middle estimate sits 14-fold (1.15 log units) above what was measured, outside the stated range (below it).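

In this assay, the group on this aromatic carbon matters: thiophen-3-yl in place of furan-3-yl gives an at least 13-fold lower number from compound 3 to compound 4 (1.14 log units; beyond the scatter). Thiophen-3-yl alone is not enough, since methyl in place of dimethylamino gives an at least 13-fold lower number from compound 2 to compound 4 (1.14 log units; beyond the scatter), and methyl in place of methylamino gives an at least 13-fold lower number from compound 1 to compound 4 (1.14 log units; beyond the scatter). Only the pairing of thiophen-3-yl with methyl gives a readable number, while the other three compounds stay at a limit of the assay: the limit of > 20000 nM in this assay, at which 3 of the 4 values shown sit.

The step between compound 1 and compound 2 cannot be read, as both are limits. Open too, from the compounds shown here alone, is how phenyl at this carbon, or ethyl in place of the methyl, would read.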